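Swapping the Hexyl Chain of Compound 2 for Phenyl

The source may hold more compounds than are shown below. What is called first, only, known or untested is meant among the compounds shown, and "the series" means these compounds.

In a functional assay on MCF7 cells (Homo sapiens) for antiproliferative activity, read by CCK-8 assay, with a stated time of 72 h (a higher number here means a weaker inhibitor, a lower number a stronger inhibitor), compound 2 `CCOc1cc(C(C)(C)C)ccc1C1=NC(c2ccc(Cl)cc2)C(c2ccc(Cl)cc2)N1C(=O)NCCCCCCCC(=O)NO` gives 7920 nM as the lower of two numbers, and compound 1 `CCOc1cc(C(C)(C)C)ccc1C1=NC(c2ccc(Cl)cc2)C(c2ccc(Cl)cc2)N1C(=O)NCCCCCCCC(=O)Nc1ccccc1N` gives 20300 nM as the other. Compound 3 `CCOc1cc(C(C)(C)C)ccc1C1=NC(c2ccc(Cl)cc2)C(c2ccc(Cl)cc2)N1C(=O)NCCCCCCC(=O)Nc1ccccc1N` gives > 100000 nM which is a limit of the assay.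

Compound 4 `CCOc1cc(C(C)(C)C)ccc1C1=NC(c2ccc(Cl)cc2)C(c2ccc(Cl)cc2)N1C(=O)NCc1ccc(C(=O)NO)cc1` alters compound 2 as follows 4-(hydroxycarbamoyl)phenyl in place of 6-(hydroxycarbamoyl)hexyl on a saturated chain carbon bound to an amide-type nitrogen and so holds 4-(hydroxycarbamoyl)phenyl in place of 6-(hydroxycarbamoyl)hexyl on a saturated chain carbon bound to an amide-type nitrogen.

The modest step of a 2.6-fold lower number from compound 1 to compound 2 (0.41 log units; beyond the scatter) concerns the end group that compound 4 keeps. The chain steps an at least 4.9-fold higher number from compound 1 to compound 3 (0.69 log units; beyond the scatter) and an at least 12-fold higher number from compound 2 to compound 3 (1.10 log units; beyond the scatter) are at least modest and large, but neither swaps a chain for a ring. A small step of a 1.5-fold higher number from compound 2 to compound 4 (0.18 log units; within the scatter) is therefore expected, within the scatter. Compound 4 is expected at 12000 nM with an estimated range from 4000 nM to 40000 nM in this assay.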

Compound 4, half-maximal inhibitory concentration: 13300 nM
Estimate against measurement, compound 4: 1.1-fold (0.04 log units) below; the range from low to high includes it.
By their numbers in this assay, from the lowest: compounds 2, 4 and 1 (each within the scatter of the next, the first and the last beyond it). At a limit, above all of these: compound 3.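

In this assay the swap of chain for ring gives a 1.7-fold higher number from compound 2 to compound 4 (0.23 log units; within the scatter), so 4-(hydroxycarbamoyl)phenyl and 6-(hydroxycarbamoyl)hexyl on a saturated chain carbon bound to an amide-type nitrogen are not told apart. The earlier compounds shown here varied only the end group and the chain length, whereas this pair shows that a six-membered aromatic ring can stand in for the hexyl chain with no change beyond the scatter. Nothing shown here bears on why the two read alike. Open, going by these compounds, is whether a carboxylic acid in place of the hydroxycarbamoyl end group would read alike on the phenyl ring. Also open, on these data alone, is how a longer chain would read with the hydroxycarbamoyl end group.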